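The source may report more compounds than this note shows. Statements on the series, on what has been measured and on what is new or still open speak of the compounds shown alone.

Measured so far:
compound 1 `Cc1ccc2oc(-c3ccc(NC(=O)CN4CCN(CCN(C)C)CC4)c(C)c3)nc2c1` — 7240 nM
compound 2 `CN(C)CCCN1CCN(CC(=O)Nc2ccc(-c3nc4cc(F)ccc4o3)cc2)CC1` — 2590 nM

Of the two compounds measured in a functional assay on HT-29 cells (Homo sapiens) for cytotoxicity, read by MTT assay, with a stated time of 24 h (a lower number here means a stronger inhibitor, a higher number a weaker inhibitor), compound 1 gives the highest number, 7240 nM, while compound 2 gives 2590 nM, a gap that lies beyond the usual scatter. Compound 3 `Cc1cc(-c2nc3cc(F)ccc3o2)ccc1NC(=O)CN1CCN(CCN(C)C)CC1` has not yet been measured. It differs from compound 1 in one place: fluoro in place of methyl on an aromatic carbon. Going by the values given here, no step between measured compounds isolates this change, so the direction rests on little. A modest gain is expected, a 1.6-fold lower number from compound 1 to compound 3 (0.21 log units; within the scatter), with a wide margin. Compound 3 is estimated at 4500 nM, within a range of 1800 nM to 11000 nM.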

Compound 3, half-maximal inhibitory concentration: 6600 nM
Estimate against measurement, compound 3: 1.5-fold (0.17 log units) below; the range from low to high includes it.
By their numbers in this assay, from the lowest: compound 2; then compounds 3 and 1 (each within the scatter of the next).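

In this assay, going by these compounds alone, the replacement of 5-methyl-1,3-benzoxazol-2-yl by 5-fluoro-1,3-benzoxazol-2-yl gives a 1.1-fold lower number from compound 1 to compound 3 (0.04 log units; within the scatter) and is the first reading of this change on its own. At this place on the core of compound 1, fluoro and methyl cannot be told apart in this cytotoxicity read-out. Nothing measured here bears on the reason for this result.

On these data alone, whether a chloro group, a methoxy group or an amine at this place would separate from fluoro and methyl remains open. Also open, as far as these compounds go, is whether the same change would read alike on a core carrying a longer chain.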